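From Hydroxy to Allyl(methyl)amino on the Ring

This account rests on a few compounds, and the source may have more. Where it says the series, first, only, none or still open, it means among the compounds named here.

Values so far in a functional assay on the whole organism for positive allosteric modulation, with Mus musculus as the target (a higher number here means that more compound is needed for the effect, a lower number that less compound is needed), for two compounds:
Compound 1 `CCC(=O)N(c1ccc(Cl)c(Cl)c1)C1CCCC1O` gives 20 mg/kg as its value
Compound 2 `CCCC(=O)N(c1ccc(Cl)c(Cl)c1)C1CCCC1N(C)C` gives 0.9 mg/kg as its value

Compound 1 at 20 mg/kg has the higher number of the two, so more of it is needed for the effect. The gap down to compound 2 at 0.9 mg/kg lies beyond the usual scatter of such measurements.

Compound 3 `C=CCN(C)C1CCCC1N(C(=O)CC)c1ccc(Cl)c(Cl)c1` has yet to be measured in this assay and keeps the core of compound 1. It carries allyl(methyl)amino in place of hydroxy on a saturated ring carbon, a change summed up as allyl(methyl)amino in place of hydroxy on a saturated ring carbon in its counted form. Going by the values given here, no measured pair isolates this change, so the expectation is only a rough one. It leans on compound 2 at 0.9 mg/kg as evidence that low numbers occur in this small set, and it points downward. The expected change is an 8.0-fold lower number from compound 1 to compound 3 (0.90 log units; beyond the scatter) and would be a drop beyond the scatter. Compound 3 is estimated at 2.5 mg/kg with an expected range of 0.7 mg/kg to 9 mg/kg in this measure.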

Compound 3, dose for half-maximal effect: 6 mg/kg
Compound 3: middle estimate off by 2.4-fold (0.38 log units), on the low side; the measured number falls inside the stated range.
By their numbers in this assay, from the lowest: compound 2; then compound 3; then compound 1.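

In this assay, going by these compounds alone, the exchange of hydroxy for allyl(methyl)amino on a saturated ring carbon gives the first step that isolates this position, a 3.3-fold lower number from compound 1 to compound 3 (0.52 log units; beyond the scatter) with the rest of the core of compound 1 unchanged. The step is modest but lies beyond the scatter, so the number responds to what this carbon carries, and a group of 5 heavy atoms with 0 hydrogen-bond donors is tolerated there without any rise in the dose needed. Nothing available explains why the number falls with this change.

Within the data shown here, the single step replaces the oxygen with a nitrogen and adds the allyl and methyl groups all at once, so it leaves open how much of the drop belongs to the amine nitrogen and how much to the allyl group. A plain methylamino or a methoxy group on this same carbon, with the rest of compound 3 kept, would separate these parts, and a carboxylic acid there would show whether the position also accepts a group of a wholly different kind.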